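This account rests on a few compounds, and the source may have more. Where it says the series, first, only, none or still open, it means among the compounds named here.

Among the measured compounds shown here, compound 2 `CC[C@@H](C)[C@H](NC(=O)c1ccc(C(CC)(CC)c2ccc(OCC(=O)C(C)(C)C)c(C)c2)n1CC)C(=O)O` is one of two compounds measured in an assay on isolated protein for binding affinity to vitamin D3 receptor (Homo sapiens), with a stated time of 4 h (a higher number here means a weaker inhibitor, a lower number a stronger inhibitor), where compound 2 gives 564 nM, the higher of the two numbers. For the measured compounds named here, compound 1 `CCN(CC)CCCNC(=O)c1ccc(C(CC)(CC)c2ccc(OCC(O)C(C)(C)C)c(C)c2)n1CC` is its nearest neighbour: in this assay compound 1 gives 71.1 nM, a gap that lies beyond the scatter, although the two differ in more than one place and no single step between them is set out. Compound 3 `CC[C@@H](C)[C@H](NC(=O)c1ccc(C(CC)(CC)c2ccc(OCC(O)C(C)(C)C)c(C)c2)n1CC)C(=O)O` has not yet been measured. Compared with compound 2, compound 3 carries 1-hydroxy-2,2-dimethylpropyl in place of (tert-butyl)carbonyl on a saturated chain carbon bound to an oxygen on an aromatic ring, so the carbonyl of the side chain becomes a hydroxyl. Going by the values given here, since no measured pair isolates this change, the direction of the step is uncertain, but compound 3 shares its side chain with compound 1, whose value of 71.1 nM suggests a lower number is plausible. The expected step from compound 2 to compound 3 is a 2.6-fold lower number from compound 2 to compound 3 (0.41 log units; beyond the scatter), and compound 3 is estimated at 220 nM, within 70 nM to 700 nM.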

Compound 3, half-maximal inhibitory concentration: 389 nM
Compound 3: the middle estimate sits 1.8-fold (0.25 log units) below what was measured; the range from low to high includes it.
By their numbers in this assay, from the lowest: compound 1; then compounds 3 and 2 (each within the scatter of the next).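

In this assay, 1-hydroxy-2,2-dimethylpropyl in place of (tert-butyl)carbonyl gives a 1.4-fold lower number from compound 2 to compound 3 (0.16 log units; within the scatter), so with 1-carboxy-2-methylbutyl on the amide-type nitrogen, this assay does not separate the two groups at this position. With the 1-hydroxy-2,2-dimethylpropyl group held the same, 1-carboxy-2-methylbutyl in place of 3-(diethylamino)propyl on the amide-type nitrogen gives a 5.5-fold higher number from compound 1 to compound 3 (0.74 log units; beyond the scatter), so the gap between compound 1 and compound 2 is not a matter of the carbonyl and hydroxyl change alone. Nothing available here accounts for either step.

The compounds shown leave open whether the carbonyl and hydroxyl forms would also stay this close with 3-(diethylamino)propyl on the amide-type nitrogen. They also leave open how an ether or a primary amine would read in place of the hydroxyl.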